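Trading a methoxypyridine for a cyanofluorophenyl on a thiazole acid

The source may hold more compounds than are shown below. What is called first, only, known or untested is meant among the compounds shown, and "the series" means these compounds.

Compound 1 `COc1cc(-c2nc(C(c3ccc(F)cc3)c3ccc(F)cc3)sc2CC(=O)O)ccn1` is a carboxylic acid built on a shared core that carries a 2-methoxypyridin-4-yl group. In an in vitro functional assay on HEK285-7 cells for antagonist activity at prostaglandin D2 receptor 2 (Homo sapiens), read by BRET and beta-arrestin recruitment (on this read-out lower numbers stand for smaller maximal responses and higher numbers for larger maximal responses), compound 1 reaches 60%. Two relatives on the same core have also been tested: compound 2 `O=C(O)Cc1sc(COc2ccc(Cl)cc2)nc1-c1ccc(Cl)cc1` reaches 50% in this assay, and compound 3 `O=C(O)Cc1sc(C(c2ccccc2)c2ccccn2)nc1-c1ccc(Cl)cc1` reaches 55%. Numerically compound 1 gives the highest of the three readings, yet its gaps to compound 3 and to compound 2 both fall within the usual scatter, so the three compounds cannot really be told apart on efficacy.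

Compound 4 `N#Cc1cc(-c2nc(C(c3ccc(F)cc3)c3ccc(F)cc3)sc2CC(=O)O)ccc1F` has not yet been measured. It differs from compound 1 in one place: 3-cyano-4-fluorophenyl in place of 2-methoxypyridin-4-yl on an aromatic carbon. Going by the values given here, no measured pair in this set isolates a change of this kind, so there is nothing to calibrate against. With all three known compounds sitting close together, the step from compound 1 to compound 4 is expected to be a number 5 percentage points lower from compound 1 to compound 4 (within the scatter), that is, no change beyond the scatter. Compound 4 is therefore estimated to reach about 55% in this assay, most likely between 40% and 70%.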

Compound 4, largest response reached (reported as efficacy), in percent of the reference or control that the assay uses: 80%
The estimate for compound 4 lay 25 percentage points below the measured number, outside the stated range (above it).
By their numbers in this assay, from the lowest: compounds 2, 3 and 1 (each within the scatter of the next); then compound 4.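

Going by these compounds alone, this is the first change in one place in the set, and it shows that the group on this aromatic carbon, next to the ring nitrogen, can move the read-out: in this assay, 3-cyano-4-fluorophenyl in place of 2-methoxypyridin-4-yl gives a number 20 percentage points higher from compound 1 to compound 4 (beyond the scatter), a larger maximal response. The earlier compounds shown here could not show this, as none of them formed a pair differing in a single place. The exchange alters the ring atoms and the attached groups together, and no measurement on hand ties the rise to any one of these features.

The compounds shown leave open whether the nitrile or the fluorine carries the step, and whether a primary amide or a trifluoromethyl group in place of the nitrile would give a similar response. Also open, going by these compounds, is whether the same exchange would have a similar effect with other groups elsewhere on the shared core.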